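Compound 3 and a New Group on the Sulfonyl Sulfur

The source may hold more compounds than are shown below. What is called first, only, known or untested is meant among the compounds shown, and "the series" means these compounds.

In a physicochemical assay for solubility, in phosphate buffer, with a stated time of 24 h, at pH 7.4, tested at 100 uM (on this read-out lower numbers stand for lower solubility and higher numbers for higher solubility), compound 1 (`O=C(NCc1ccc(S(=O)(=O)C2CCOCC2)cc1)N1Cc2ccncc2C1`) reads 206000 nM and compound 2 (`O=C(NCc1ccc(S(=O)(=O)C2CCN(C3COC3)CC2)cc1)N1Cc2ccncc2C1`) reads 121000 nM while compound 3 (`CN1CCC(S(=O)(=O)c2ccc(CNC(=O)N3Cc4ccncc4C3)cc2)CC1`) reads 240000 nM and so stands level with both within the scatter. Compound 4 (`O=C(NCc1ccc(S(=O)(=O)N2CCC[C@@H](O)C2)cc1)N1Cc2ccncc2C1`) differs from compound 3 by 3-hydroxypiperidin-1-yl in place of 1-methylpiperidin-4-yl on a sulfonyl sulfur. Three measured swaps at that place bear on it: a 1.7-fold lower number from compound 1 to compound 2 (0.23 log units; within the scatter) then a 1.2-fold higher number from compound 1 to compound 3 (0.07 log units; within the scatter) and finally a 2.0-fold higher number from compound 2 to compound 3 (0.30 log units; within the scatter) as the largest. None of them tried this new group, so the expectation stays loose. The estimate is a 1.5-fold lower number from compound 3 to compound 4 (0.18 log units; within the scatter) and therefore no expected step beyond the scatter in this assay for this swap. Compound 4 is expected near 160000 nM with an estimated range from 80000 nM to 280000 nM as its likely span.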

Compound 4, solubility: 216000 nM
Estimate against measurement, compound 4: 1.4-fold (0.13 log units) below; low and high end bracket the measured number.
By their numbers in this assay, from the lowest: compounds 2, 1, 4 and 3 (each within the scatter of the next).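

In this assay, 3-hydroxypiperidin-1-yl on the sulfonyl sulfur, which enters with 1 hydrogen-bond donor and 1 defined stereocentre, stays within the scatter of all three earlier groups: a 1.1-fold lower number from compound 3 to compound 4 (0.05 log units; within the scatter), a 1.8-fold higher number from compound 2 to compound 4 (0.25 log units; within the scatter) and a 1.0-fold higher number from compound 1 to compound 4 (0.02 log units; within the scatter). Across compounds 1 to 4, then, this position has taken four different groups with no step beyond the scatter. No supporting measurement gives a reason for this result. Still open, from the compounds shown here alone, is whether a group carrying a carboxylic acid at this position would give a step beyond the scatter.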